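The source may hold more compounds than are shown below. What is called first, only, known or untested is meant among the compounds shown, and "the series" means these compounds.

Measured so far:
Compound 1 `CN(C)S(=O)(=O)c1ccccc1Nc1cc(-c2ccc3ccn(C)c3c2)c2nccnc2c1`: 7670 nM
Compound 2 `Cn1cc(CNC(=O)c2ccncc2Nc2cc(-c3ccc4ccn(C)c4c3)c3nccnc3c2)cn1`: 75900 nM

Both numbers come from an assay on lysate for inhibition of 6-phosphofructo-2-kinase/fructose-2,6-bisphosphatase 3 (Homo sapiens), with stated times of 0.5 min and 45 min; a higher number here means a weaker inhibitor, a lower number a stronger inhibitor. Compound 2 has the higher of the two numbers. Within the data shown here, its only neighbour is compound 1, whose number is lower by a gap that lies beyond the usual scatter of this kind of measurement, so compound 2 is the weaker inhibitor of the pair.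

Compound 3 `CN1CC(NC(=O)c2ccncc2Nc2cc(-c3ccc4ccn(C)c4c3)c3nccnc3c2)CCC1=O` is built on the same core as compound 2 and differs from it in one place: 1-methyl-6-oxopiperidin-3-yl in place of (1-methyl-1H-pyrazol-4-yl)methyl on an amide-type nitrogen. Among the measured compounds shown here, no measured pair shows this particular exchange, so nothing in the data tells how large a shift it brings or in which direction. The expectation for compound 3 therefore rests on compound 2 alone, with no more than the ordinary scatter added for the swap of one amide substituent for another of similar size. Compound 3 is expected to give about 60000 nM in this assay, with a range from 20000 nM to 180000 nM. This estimate means a step of a 1.3-fold lower number from compound 2 to compound 3 (0.10 log units; within the scatter), which is expected to stay within the usual scatter.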

Compound 3, half-maximal inhibitory concentration: 96500 nM
Compound 3: middle estimate off by 1.6-fold (0.21 log units), on the low side, within the range that was stated.
By their numbers in this assay, from the lowest: compound 1; then compounds 2 and 3 (each within the scatter of the next).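

On the amide-type nitrogen, putting 1-methyl-6-oxopiperidin-3-yl in place of (1-methyl-1H-pyrazol-4-yl)methyl gives a 1.3-fold higher number from compound 2 to compound 3 (0.10 log units; within the scatter) in this assay, so this pair cannot be told apart by this measurement. The exchange is a sizeable one on paper: a five-membered aromatic ring with 2 hetero atoms gives way to a six-membered non-aromatic ring with 1 hetero atom, and the count of hydrogen-bond acceptors goes from 2 to 1, yet no shift beyond the scatter follows in this single pair. No separate measurement is available that would help interpret this result.

Going by these compounds, what remains open is whether any group on this nitrogen can move the number beyond the scatter, for example a plain methyl, a longer chain ending in an amine, or one ending in a carboxylic acid. On these data alone, it is also open whether the same exchange would give a similar result on a different core, since this one pair says nothing beyond the core it shares.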